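From Formyl to Diethylcarbamoyl on an Aromatic Nitrogen

This account rests on a few compounds, and the source may have more. Where it says the series, first, only, none or still open, it means among the compounds named here.

Compound 1, `COc1cc(C(=O)NS(=O)(=O)c2ccccc2C)ccc1Cc1cn(C(F)F)c2ccc(NC(=O)OC3CCCC3)cc12`: 0.4 nM
Compound 2, `COc1cc(C(=O)NS(=O)(=O)c2ccccc2C)ccc1Cc1cn(C=O)c2ccc(NC(=O)OC3CCCC3)cc12`: 0.6 nM
Compound 3, `COc1cc(C(=O)NS(=O)(=O)c2ccccc2C)ccc1Cc1c[nH]c2ccc(NC(=O)OC3CCCC3)cc12`: 2 nM

Three compounds share one core and differ only in the group carried on an aromatic nitrogen. In a functional assay on U-937 cells (Homo sapiens) (a higher number here means a weaker inhibitor, a lower number a stronger inhibitor), compound 1 gives 0.4 nM, compound 2 gives 0.6 nM and compound 3 gives 2 nM. Compound 2 thus stands second highest of the three numbers: the step of a 1.5-fold higher number from compound 1 to compound 2 (0.18 log units; within the scatter) lies within the scatter, whereas a 3.3-fold higher number from compound 2 to compound 3 (0.52 log units; beyond the scatter) and a 5.0-fold higher number from compound 1 to compound 3 (0.70 log units; beyond the scatter) lie beyond it.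

Compound 4, `CCN(CC)C(=O)n1cc(Cc2ccc(C(=O)NS(=O)(=O)c3ccccc3C)cc2OC)c2cc(NC(=O)OC3CCCC3)ccc21`, is not yet measured. It differs from compound 2 in one place: diethylamino in place of hydrogen on a carbonyl carbon. The measured steps bear on this only loosely. They show that a hydrogen on the aromatic nitrogen gives a higher number than formyl or difluoromethyl, while formyl and difluoromethyl cannot be told apart within the scatter. Among the compounds with values here, no step shows what a larger group on the carbonyl carbon does. The expectation is therefore a step of a 1.3-fold higher number from compound 2 to compound 4 (0.12 log units; within the scatter) that stays close to the scatter. Compound 4 is estimated at 0.8 nM, with a range from 0.3 nM to 2.5 nM.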

Compound 4, half-maximal inhibitory concentration: 0.8 nM
The estimate for compound 4 equals the measured number at the digits printed; the measured number falls inside the stated range.
By their numbers in this assay, from the lowest: compounds 1, 2 and 4 (each within the scatter of the next); then compound 3.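

In this assay, diethylamino in place of hydrogen on the carbonyl carbon gives a 1.3-fold higher number from compound 2 to compound 4 (0.12 log units; within the scatter) even though 5 heavy atoms enter where a hydrogen leaves, so this position tolerates a far bigger group than the formyl hydrogen. Diethylcarbamoyl on the aromatic nitrogen also holds up against the other two groups: replacing hydrogen with it gives a 2.5-fold lower number from compound 3 to compound 4 (0.40 log units; beyond the scatter) and replacing difluoromethyl with it gives a 2.0-fold higher number from compound 1 to compound 4 (0.30 log units; within the scatter) so it joins formyl and difluoromethyl as a group that cannot be told apart from them here. Nothing available explains why these different groups give such similar numbers.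

From the compounds shown here alone, whether the carbonyl itself matters remains open, and a plain ethyl or longer alkyl chain on the aromatic nitrogen would address that. Going by these compounds, how far the carbonyl carbon tolerates other groups also remains open, for example a cyclic amine such as morpholine or a chain ending in a carboxylic acid.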